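Piperazine amides on HL-60 cells: the halogenated analogue

The source may hold more compounds than are shown below. What is called first, only, known or untested is meant among the compounds shown, and "the series" means these compounds.

Three compounds of the series have numbers in a functional assay on HL-60 cells (Homo sapiens) for inhibition, read by MTT assay, with a stated time of 72 h; on this read-out higher numbers stand for weaker inhibition and lower numbers for stronger inhibition. Compound 1 `Cc1ccc(N2CCN(C(=O)c3oc(C)nc3-c3ccccc3)CC2)c(C)c1` gives 101 nM and stands at the lowest of the three numbers, though the gaps to the other two lie within the scatter. Compound 2 `Cc1nc(-c2ccccc2F)c(C(=O)N2CCN(c3cc(Cl)cc(Cl)c3)CC2)s1` gives 157 nM, and compound 3 `COc1cc(OC)cc(N2CCN(C(=O)c3onc(C)c3-c3ccccc3F)CC2)c1` gives 165 nM. No pair among these differs in only one place, so no single-point step is known.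

The next compound, compound 4 `Cc1nc(-c2ccccc2)c(C(=O)N2CCN(c3cccc(Cl)c3)CC2)o1`, keeps the core of compound 1 and changes only the group on the amine nitrogen in the ring of the six-membered non-aromatic ring with two nitrogens: 3-chlorophenyl in place of 2,4-dimethylphenyl on an amine nitrogen in a ring. Compound 2, which also carries chlorine on its ring on that nitrogen, gives a number close to that of compound 1, so no step beyond the scatter is expected from compound 1 to compound 4, with a 1.3-fold higher number from compound 1 to compound 4 (0.11 log units; within the scatter) as the expected change. In this assay compound 4 is expected to give 130 nM, in the range 50 nM to 400 nM.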

Compound 4, half-maximal inhibitory concentration: 39.2 nM
Estimate against measurement, compound 4: 3.3-fold (0.52 log units) above; the measured number lies below the stated range.
By their numbers in this assay, from the lowest: compound 4; then compounds 1, 2 and 3 (each within the scatter of the next).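

In this assay, the group on the amine nitrogen in a ring turns out to be a place where the number moves beyond the scatter: 3-chlorophenyl in place of 2,4-dimethylphenyl gives a 2.6-fold lower number from compound 1 to compound 4 (0.41 log units; beyond the scatter) with the core of compound 1 held unchanged. Going by these compounds alone, this is the only single-point step known, so the earlier compounds could not tie any difference to this group alone. Nothing measured on hand accounts for the step, and its origin stays unassigned.

The change removes two methyl groups and adds one chlorine, so the step cannot be divided between the loss and the gain. Open too, from the compounds shown here alone, is how an unsubstituted phenyl or a 3-trifluoromethylphenyl on this nitrogen would read, and whether the step holds on the other cores.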